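Swapping a dichlorobenzyl for a fluorobenzyl on a shared core

This account rests on a few compounds, and the source may have more. Where it says the series, first, only, none or still open, it means among the compounds named here.

Measured compounds:
compound 1, `Nc1cc(N)c2nc(-c3ccccc3)c(NCc3ccc(Cl)c(Cl)c3)nc2c1`, 72400 nM
compound 2, `CCOC(=O)[C@H](CCC(=O)O)NC(=O)c1ccc(Oc2nc3cc(N)cc(N)c3nc2-c2ccccc2)cc1`, < 50200 nM (a limit of the assay, not a number)

The measurement is a functional assay on TK-10 cells (Homo sapiens) for inhibition, read by sulforhodamine B assay, with a stated time of 48 h; a higher number here means that more compound is tolerated, a lower number that less compound is tolerated. For the measured compounds named here, compound 1 gives 72400 nM, the only plain number in the set. Compound 2 reaches only < 50200 nM, which is a limit of the assay and not a number; the note the limit of < 50200 nM in this assay, at which 1 of the 2 values shown sits, records that one of the two values sits at this limit. Nothing is computed between compound 1 and compound 2, and the two can only be set side by side.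

Compound 3, `Nc1cc(N)c2nc(-c3ccccc3)c(NCc3ccc(F)cc3)nc2c1`, has not been measured. It differs from compound 1 by 4-fluorophenyl in place of 3,4-dichlorophenyl on a saturated chain carbon bound to a nitrogen on an aromatic ring. Going by the values given here, no measured step of this kind exists in the set, so the expectation rests on compound 1 alone. The step from compound 1 to compound 3 is expected to be small, a 1.2-fold higher number from compound 1 to compound 3 (0.09 log units; within the scatter), and not clearly beyond the scatter, with a slight lean toward more compound being tolerated. Compound 3 is therefore estimated at 90000 nM, within a range from 35000 nM to 250000 nM.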

Compound 3, concentration lethal to 50% of the cells: 53700 nM
Compound 3: middle estimate off by 1.7-fold (0.22 log units), on the high side; low and high end bracket the measured number.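

In this assay, for the compounds shown here, putting 4-fluorophenyl in place of 3,4-dichlorophenyl on a saturated chain carbon bound to a nitrogen on an aromatic ring gives a 1.3-fold lower number from compound 1 to compound 3 (0.13 log units; within the scatter) and is the only step in the set that can be read. Going by these compounds alone, it shows that, on the shared core, this exchange of one halogen-bearing phenyl for another leaves the two compounds indistinguishable in this assay even though both chlorines leave and a fluorine enters, something compound 1 could not show while it stood alone as the only plain number. Nothing available gives a cause for the size of this step.

The compounds shown leave open whether a phenyl without any halogen, a phenyl carrying a methoxy group or an amine, or a longer chain between the nitrogen and the phenyl would shift the number beyond the scatter on this core. Compound 2 gives only a limit of the assay and not a number, so the steps that would involve it cannot be read.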